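Replacing 3-ethynylphenyl with 4-cyclopropylphenyl

This account rests on a few compounds, and the source may have more. Where it says the series, first, only, none or still open, it means among the compounds named here.

In a physicochemical assay for solubility, read by turbidimetry, measured as kinetic solubility, at pH 7.4 (on this read-out higher numbers stand for higher solubility and lower numbers for lower solubility), compound 1 `O=C(NCCCCn1cccn1)c1cccc(C2SCC(=O)N2c2ccccn2)c1` gives 50000 nM. Compound 2 `O=C(NCCCCc1ccccc1)c1cccc(C2SCC(=O)N2c2cccc(-c3c[nH]nn3)c2)c1` gives 20000 nM. Compound 3 `C#Cc1cccc(N2C(=O)CSC2c2cccc(C(=O)NCCCCc3ccccc3)c2)c1` gives 10000 nM, which places it level with compound 2 within the scatter and well under compound 1. Compound 4 `O=C(NCCCCc1ccccc1)c1cccc(C2SCC(=O)N2c2ccc(C3CC3)cc2)c1` differs from compound 3 by 4-cyclopropylphenyl in place of 3-ethynylphenyl on an amide-type nitrogen in a ring. Among the compounds with values here, only one measured step touches this group, a 2.0-fold lower number from compound 2 to compound 3 (0.30 log units; within the scatter), and it stayed within the scatter while exchanging a different substituent. It offers weak guidance, so no shift beyond the scatter is expected. The estimated change is a 1.3-fold lower number from compound 3 to compound 4 (0.10 log units; within the scatter). Compound 4 is expected at 8000 nM, with an estimated range from 3000 nM to 20000 nM.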

Compound 4, solubility: 2000 nM
Compound 4: the middle estimate sits 4.0-fold (0.60 log units) above what was measured; measured number outside the range, below it.
By their numbers in this assay, from the lowest: compound 4; then compounds 3 and 2 (each within the scatter of the next); then compound 1.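

Within the data shown here, at the amide-type nitrogen in the ring, the aromatic group clearly matters: in this assay the exchange of 3-ethynylphenyl for 4-cyclopropylphenyl gives a 5.0-fold lower number from compound 3 to compound 4 (0.70 log units; beyond the scatter) and is the first step at this position beyond the scatter. Set against the triazole-bearing group, the change gives a 10-fold lower number from compound 2 to compound 4 (1.00 log units; beyond the scatter) and is larger still. Nothing measured here accounts for either step.

The exchange alters both the substituent and where it sits on the phenyl ring, and these compounds do not separate the two. A 3-cyclopropylphenyl group or a phenyl ring carrying a carboxylic acid at this position remains an open case.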